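Swapping One Halogenated Phenyl Group for Another

This account rests on a few compounds, and the source may have more. Where it says the series, first, only, none or still open, it means among the compounds named here.

Of the compounds shown here, two with a shared core have been measured so far. In a functional assay on A549 cells (Homo sapiens) for cytotoxicity, read by MTT assay, with a stated time of 72 h (a lower number here means a stronger inhibitor, a higher number a weaker inhibitor), compound 1 `CNC(=O)c1cc(Oc2ccc(C3=NNC(c4cccc(Br)c4)C3)cc2)ccn1` gives 2840 nM, the lower of the two numbers, and compound 2 `CNC(=O)c1cc(Oc2ccc(C3=NNC(c4cc(OC)c(OC)c(OC)c4)C3)cc2)ccn1` gives 37100 nM. That gap lies well beyond the usual scatter of repeated measurements, so compound 1 is the stronger inhibitor of the pair.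

The next compound, compound 3 `CNC(=O)c1cc(Oc2ccc(C3=NNC(c4ccc(F)cc4Cl)C3)cc2)ccn1`, changes one group of compound 1: 2-chloro-4-fluorophenyl in place of 3-bromophenyl on a saturated ring carbon. Here 2-chloro-4-fluorophenyl stands in place of 3-bromophenyl on a saturated ring carbon. Both groups are halogen-bearing phenyl rings with no net charge. Going by the values given here, no measured pair shows this kind of swap, so the forecast is a judgement and its range is wide. The estimated step of a 1.2-fold higher number from compound 1 to compound 3 (0.09 log units; within the scatter) is expected to stay within the scatter, in neither direction. For compound 3 the expected value is 3500 nM, with an estimated range of 1200 nM to 11000 nM.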

Compound 3, half-maximal inhibitory concentration: 13700 nM
Estimate against measurement, compound 3: 3.9-fold (0.59 log units) below, outside the stated range (above it).
By their numbers in this assay, from the lowest: compound 1; then compound 3; then compound 2.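

In this assay, this saturated ring carbon proves sensitive even to a swap between two halogen-bearing phenyl groups: 2-chloro-4-fluorophenyl in place of 3-bromophenyl gives a 4.8-fold higher number from compound 1 to compound 3 (0.68 log units; beyond the scatter). The earlier pair could only set the 3-bromophenyl group against a ring carrying methoxy groups, whereas this step shows that having halogens on the phenyl ring does not by itself fix the number. No measurement here accounts for the size of this step.

The swap changes the kind, number and placing of the halogens all at once, and these compounds do not separate those changes. From the compounds shown here alone, how a plain phenyl group, a 3-chlorophenyl group or a phenyl ring bearing an amine would behave at this position remains open.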